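A Ring-Bearing Carbonyl Group Replaces a Hydroxypropyl Chain

This account rests on a few compounds, and the source may have more. Where it says the series, first, only, none or still open, it means among the compounds named here.

Compound 1 `CC(C)=CC[C@@H](OC[C@@H](C)O)C1=CC(=O)c2c(O)ccc(O)c2C1=O` shares its core with compound 2 `CC[C@@](C)(O)CC(=O)O[C@H](CC=C(C)C)C1=CC(=O)c2c(O)ccc(O)c2C1=O` and compound 3 `CCCC(O)CC(=O)O[C@H](CC=C(C)C)C1=CC(=O)c2c(O)ccc(O)c2C1=O`; the three differ only in the group attached through an oxygen on a saturated carbon. In a functional assay on HeLa cells (Homo sapiens) for cytotoxicity, read by MTT assay (a lower number here means a stronger inhibitor, a higher number a weaker inhibitor), compound 1 gives 22500 nM, compound 2 gives 17900 nM, and compound 3 gives 59300 nM. Compound 1 thus holds the second highest of the three numbers: its gap to compound 2 lies within the scatter, while its gap to compound 3 is modest but beyond it.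

Compound 4 `CC(C)=CC[C@@H](OC(=O)C1CCCCO1)C1=CC(=O)c2c(O)ccc(O)c2C1=O` arises from compound 1 by a single change: (oxan-2-yl)carbonyl in place of 2-hydroxypropyl on an oxygen on a saturated carbon. The 2-hydroxypropyl chain gives way to a group joined through a carbonyl and carrying a six-membered non-aromatic ring with one hetero atom, and the hydrogen-bond donor is lost.

Among the compounds with values here, two measured steps bear on this. The step of a 1.3-fold lower number from compound 1 to compound 2 (0.10 log units; within the scatter) also trades the 2-hydroxypropyl for a carbonyl-linked group and barely moves the number. The step of a 2.6-fold higher number from compound 1 to compound 3 (0.42 log units; beyond the scatter) makes the same kind of trade and raises the number modestly. Compound 4 keeps the carbonyl link but lacks the hydrogen-bond donor that compound 2 and compound 3 retain, so the measured compounds do not settle the direction. The expected step is a 1.2-fold higher number from compound 1 to compound 4 (0.08 log units; within the scatter), small and probably within the scatter. Compound 4 is therefore estimated at 27000 nM in this assay, with a range from 10000 nM to 70000 nM.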

Compound 4, half-maximal inhibitory concentration: > 100000 nM
Compound 4 was reported as a limit; the forecaster's own chance of this, stated with the estimate: 5%; at least 3.7-fold (0.56 log units) between middle value and limit.
By their numbers in this assay, from the lowest: compounds 2 and 1 (each within the scatter of the next); then compound 3. At a limit, above all of these: compound 4.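

Compound 4 stands only as a limit in this assay: the limit of > 100000 nM in this assay, at which 1 of the 4 values shown sits.

Replacing 2-hydroxypropyl with (oxan-2-yl)carbonyl on this oxygen gives an at least 4.4-fold higher number from compound 1 to compound 4 (0.64 log units; beyond the scatter), and swapping the group on the carbonyl carbon for oxan-2-yl gives an at least 5.5-fold higher number from compound 2 to compound 4 (0.74 log units; beyond the scatter), so the carbonyl link alone does not set the result at this position: compound 2 has that link and stays within the scatter of compound 1, while compound 4 has it and does not. The comparison with the other hydroxyl-bearing carbonyl compound is less sharp, at an at least 1.6-fold higher number from compound 3 to compound 4 (0.22 log units; that floor lies within the scatter), so this step alone does not separate those two compounds.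

The change brings in the six-membered ring and removes the hydrogen-bond donor together, and the compounds shown cannot tell which of the two accounts for the loss. A plain pentyl chain on the carbonyl, with no hydroxyl and no ring, would test the donor on its own, and an oxan-2-yl ring bearing a hydroxyl would test the ring on its own.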